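This account rests on a few compounds, and the source may have more. Where it says the series, first, only, none or still open, it means among the compounds named here.

Measured in a functional assay on HCT-116 cells (Homo sapiens), read by MTT assay, with a stated time of 72 h; on this read-out higher numbers stand for weaker inhibition and lower numbers for stronger inhibition:
- Compound 1 `C#Cc1cn([C@@H]2O[C@H](CO)[C@@H](O)[C@H]2O)c2ncnc(SC)c12`: 30 nM
- Compound 2 `CN(C)c1ncnc2c1c(-c1cc3ccccc3o1)cn2[C@@H]1O[C@H](CO)[C@@H](O)[C@H]1O`: > 20000 nM (a limit)

Compound 2 gives no number in this assay, only the limit > 20000 nM. Compound 3 `C#Cc1cn([C@@H]2O[C@H](CO)[C@@H](O)[C@H]2O)c2ncnc(N(C)C)c12` carries ethynyl in place of 1-benzofuran-2-yl on an aromatic carbon. Going by the values given here, no measured pair isolates this change. Compound 1, which also bears ethynyl, gives 30 nM, so much stronger inhibition is expected in compound 3. The estimated step, an at least 20-fold lower number from compound 2 to compound 3 (1.30 log units; beyond the scatter), points towards lower numbers, and its size is uncertain. Compound 3 is expected at 1000 nM, with an estimated range of 80 nM to 15000 nM.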

Compound 3, half-maximal inhibitory concentration: 180 nM
Compound 3: the middle estimate sits 5.6-fold (0.74 log units) above what was measured; the measured number falls inside the stated range.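

In this assay, ethynyl in place of 1-benzofuran-2-yl on this aromatic carbon, with dimethylamino kept, gives an at least 110-fold lower number from compound 2 to compound 3 (2.04 log units; beyond the scatter). From the compounds shown here alone, the full size of this step stays open, as compound 2 gives only a limit: the limit of > 20000 nM in this assay, at which 1 of the 3 values shown sits. With ethynyl kept, dimethylamino in place of methylsulfanyl on an aromatic carbon gives a 6.0-fold higher number from compound 1 to compound 3 (0.78 log units; beyond the scatter), a modest step beside the large one.

The compounds shown leave open whether methyl or phenyl on this carbon would behave more like ethynyl or more like 1-benzofuran-2-yl.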